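This account rests on a few compounds, and the source may have more. Where it says the series, first, only, none or still open, it means among the compounds named here.

Compound 3 `COC(=O)C1=C(Nc2ccccc2Cl)O/C(=C\c2c[nH]c3ncccc23)C1=O` gives the highest number of the three measured compounds in an ADME assay on microsomes from liver (Rattus norvegicus) for metabolic stability, read by LC-MS, using NADPH, with a stated time of 30 min, tested at 1 uM (a lower number here means that less of the compound is left, a higher number that more of the compound is left), namely 58%. Compound 2 `COC(=O)C1=C(Nc2ccc(C)cc2C)O/C(=C\c2c[nH]c3ncccc23)C1=O` is next with 30%, and compound 1 `COC(=O)C1=C(Nc2ccc(OC)cc2)O/C(=C\c2c[nH]c3ncccc23)C1=O` is lowest with 5.1%. The steps are a number 28 percentage points higher from compound 2 to compound 3 (beyond the scatter), a number 52.9 percentage points higher from compound 1 to compound 3 (beyond the scatter) and a number 24.9 percentage points higher from compound 1 to compound 2 (beyond the scatter). Compound 4 `COC(=O)C1=C(Nc2ccccc2C)O/C(=C\c2c[nH]c3ncccc23)C1=O` differs from compound 3 by methyl in place of chloro on an aromatic carbon. The step that bears most directly on it is the one in which a chloro-bearing aryl replaced a methyl-bearing aryl, the step from compound 2 to compound 3, a modest gain; the reverse direction is therefore expected here. A modest fall in this assay is expected, as a number 23 percentage points lower from compound 3 to compound 4 (beyond the scatter). For compound 4 the estimate in this assay is 35%, with a range from 15% to 60%.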

Compound 4, percent of the compound remaining: 24%
Estimate against measurement, compound 4: 11 percentage points above; measured number inside the range.
By their numbers in this assay, from the lowest: compound 1; then compounds 4 and 2 (each within the scatter of the next); then compound 3.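

In this assay the exchange of chloro for methyl, ortho to a large group, gives a number 34 percentage points lower from compound 3 to compound 4 (beyond the scatter) and so shows that the number of compound 3 does not carry over to any small group at this place. The further methyl of compound 2 counts for little, with a number 6 percentage points lower from compound 2 to compound 4 (within the scatter) on its loss, while a number 18.9 percentage points higher from compound 1 to compound 4 (beyond the scatter) shows that 2-methylphenyl alone keeps a gain over 4-methoxyphenyl. No measurement given here accounts for these steps. As far as these compounds go, whether fluoro, bromo or an amine at this place would stand with chloro or with methyl remains open.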